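Changing the group on the five-membered ring of compound 3

A few compounds are considered here, and "the series" means these few. Any claim that something is new, unique, unknown or untested is made for them only; others in the source may bear on it.

- compound 1 `CC(=O)N[C@H]1CC[C@H](Nc2cc(-c3csc(NCC4CCOCC4)n3)c(Cl)cn2)CC1` gives 3600 nM
- compound 2 `CCOCCN[C@H]1CC[C@H](Nc2cc(-c3csc(NCC4CCOCC4)n3)c(Cl)cn2)CC1` gives 497 nM
- compound 3 `COCCN[C@H]1CC[C@H](Nc2cc(-c3csc(OCC4CCOCC4)n3)c(Cl)cn2)CC1` gives 570 nM

In a functional assay on MV4-11 cells (Homo sapiens) for antiproliferative activity, read by CellTiter-Glo, with a stated time of 72 h (on this read-out lower numbers stand for stronger inhibition of growth and higher numbers for weaker inhibition of growth), compound 3 stands at 570 nM, within the scatter of compound 2 at 497 nM, while compound 1 at 3600 nM has a clearly higher number than either. Compound 4 `COCCN[C@H]1CC[C@H](Nc2cc(-c3csc(NCc4ccc(F)cc4)n3)c(Cl)cn2)CC1` has not yet been measured. Its structure differs from that of compound 3 by (4-fluorobenzyl)amino in place of (oxan-4-yl)methoxy on an aromatic carbon on an aromatic carbon of the five-membered aromatic ring.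

Going by the values given here, the only measured step, a 7.2-fold lower number from compound 1 to compound 2 (0.86 log units; beyond the scatter), lies on an amine nitrogen and not at this place, so it offers no direct guide. Among the compounds with values here, no measured compound carries the (4-fluorobenzyl)amino group. Within the data shown here, no step clearly beyond the scatter is therefore expected in this assay, with only a slight lean towards a lower number. The expected step is a 1.9-fold lower number from compound 3 to compound 4 (0.28 log units; within the scatter), and this remains a loose estimate. For compound 4 the estimated value is 300 nM, with an expected range from 70 nM to 1200 nM.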

Compound 4, concentration for 50% growth inhibition: 880 nM
Estimate against measurement, compound 4: 2.9-fold (0.47 log units) below; the measured number falls inside the stated range.
By their numbers in this assay, from the lowest: compounds 2, 3 and 4 (each within the scatter of the next); then compound 1.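

In this assay, the exchange of (oxan-4-yl)methoxy for (4-fluorobenzyl)amino on an aromatic carbon of the five-membered aromatic ring gives a 1.5-fold higher number from compound 3 to compound 4 (0.19 log units; within the scatter) and so stays within the scatter. Going by these compounds alone, this is the first reading at this position, and it shows that a six-membered non-aromatic ring with 1 hetero atom can give way to a six-membered aromatic ring of carbon only, with a hydrogen-bond donor added, without a clear shift in growth inhibition. Nothing measured here bears on why the number holds across this exchange. The compounds shown do not separate the linking oxygen or nitrogen from the ring that follows it. They also leave open how a small group at this place, such as a plain amino group or a methyl group, would read.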